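Trimming the oxolane to a methyl on the benzylic carbon

The source may hold more compounds than are shown below. What is called first, only, known or untested is meant among the compounds shown, and "the series" means these compounds.

Compound 1, with the structure `Cc1cc(C)c(CN2CCc3c(Cl)cc([C@@H](CO)[C@@H]4CCOC4)c(Cl)c3C2=O)c(=O)[nH]1`, is tested in a functional assay on KARPAS-422 cells (Homo sapiens) for antiproliferative activity, read by resazurin assay, with a stated time of 72 h (on this read-out lower numbers stand for stronger inhibition and higher numbers for weaker inhibition), where compound 1 gives 3950 nM. That is the highest of the two single numbers in this assay. The nearest neighbour is compound 3, `COc1cc(C)[nH]c(=O)c1CN1CCc2c(Cl)cc([C@H](O)C3COC3)c(Cl)c2C1=O`, which in this assay gives 108 nM, a gap that lies beyond the scatter. Compound 2, `COC(c1cc(Cl)c2c(c1Cl)C(=O)N(Cc1c(C)cc(C)[nH]c1=O)CC2)C1CCN(C2COC2)CC1`, has no single number here: its entries in this assay read 2260 nM; 25 nM (2 entries), as recorded in the several entries of compound 2 in this assay, 2260 nM; 25 nM (2 entries), and they lie far apart.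

The step under study leads from compound 1 to compound 4, `Cc1cc(C)c(CN2CCc3c(Cl)cc([C@H](C)CO)c(Cl)c3C2=O)c(=O)[nH]1`, which has not yet been measured in this assay. The change is methyl in place of oxolan-3-yl on a saturated chain carbon bound to an aromatic carbon and a saturated chain carbon. Going by the values given here, no measured pair in the set differs in only this one place, so the size of the step cannot be read off another example.

The author expects the loss of the oxolan-3-yl group, with its single hydrogen-bond acceptor, to cost rather than gain activity, though a step within the scatter is also plausible. The step from compound 1 to compound 4 is expected to be a 1.5-fold higher number from compound 1 to compound 4 (0.18 log units; within the scatter). In this assay compound 4 is therefore estimated at 6000 nM, within a range from 1500 nM to 24000 nM.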

Compound 4, half-maximal inhibitory concentration: 186 nM
Compound 4: middle estimate off by 32-fold (1.51 log units), on the high side; the whole stated range lies above it.
By their numbers in this assay, from the lowest: compounds 3 and 4 (each within the scatter of the next); then compound 1.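

In this assay, this position proves highly sensitive to the group it carries: with methyl in place of oxolan-3-yl on a saturated chain carbon bound to an aromatic carbon and a saturated chain carbon, the result is a 21-fold lower number from compound 1 to compound 4 (1.33 log units; beyond the scatter). Going by these compounds alone, the oxolan-3-yl group is therefore not required for activity at this place, and the much smaller methyl is clearly preferred in this pair, something the earlier compounds could not show, as no two of them differed in only one place. A single step of this size still calls for some caution, since the entries for one compound in the same assay lie far apart: the several entries of compound 2 in this assay, 2260 nM; 25 nM (2 entries).

The change removes a ring, a hydrogen-bond acceptor and a defined stereocentre together, and the compounds shown do not separate these features or reveal a cause for the step. Going by these compounds, it also remains open how an ethyl, a cyclopropyl or a methoxymethyl group would behave on this carbon, and whether methyl is the best group there.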